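A few compounds are considered here, and "the series" means these few. Any claim that something is new, unique, unknown or untested is made for them only; others in the source may bear on it.

Measured so far, in a functional assay on HeLa cells (Homo sapiens) for cytotoxicity, with a stated time of 72 h; a lower number here means a stronger inhibitor, a higher number a weaker inhibitor: compound 1 `O=[N+]([O-])c1ccc(-c2cn3nc(Cc4ccc(Cl)cc4)sc3n2)cc1` gives > 250000 nM, which is a limit of the assay and not a number. Compound 2 `O=Cc1c(-c2ccc(F)cc2)nc2sc(Cc3ccc(Cl)cc3)nn12` gives 20000 nM. Compound 3 `O=Cc1c(-c2ccc(Cl)cc2Cl)nc2sc(Cc3ccc(Cl)cc3)nn12` gives 64000 nM.

Compound 3 thus stands at the highest of the two numbers shown, the weaker of the two measured inhibitors; its nearest neighbour is compound 2, and the step between them is a 3.2-fold higher number from compound 2 to compound 3 (0.51 log units; beyond the scatter). Compound 4 `O=Cc1c(-c2ccc([N+](=O)[O-])cc2)nc2sc(Cc3ccc(Cl)cc3)nn12` differs from compound 3 in one place: 4-nitrophenyl in place of 2,4-dichlorophenyl on an aromatic carbon. Among the measured compounds shown here, the only measured step at this position is the swap of one aryl group for another, a 3.2-fold higher number from compound 2 to compound 3 (0.51 log units; beyond the scatter), a modest shift. Compound 1 carries the same 4-nitrophenyl group as compound 4 but lacks the formyl group, and it reaches only (the limit of > 250000 nM in this assay, at which 1 of the 3 values shown sits). From this, compound 4 is expected to sit close to compound 3 or somewhat weaker, a step of a 1.3-fold higher number from compound 3 to compound 4 (0.10 log units; within the scatter). The estimate for compound 4 is 80000 nM, with a range from 25000 nM to 250000 nM, and a real chance that only a limit is reported.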

Compound 4, half-maximal inhibitory concentration: 17000 nM
Compound 4: middle estimate off by 4.7-fold (0.67 log units), on the high side; the measured number lies below the stated range.
By their numbers in this assay, from the lowest: compounds 4 and 2 (each within the scatter of the next); then compound 3. At a limit, above all of these: compound 1.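

In this assay, the new result shows that the aryl group at this position can shift the number, but not every swap does: a 3.8-fold lower number from compound 3 to compound 4 (0.58 log units; beyond the scatter), whereas 4-nitrophenyl and 4-fluorophenyl cannot be told apart, with a 1.2-fold lower number from compound 2 to compound 4 (0.07 log units; within the scatter). So 2,4-dichlorophenyl is the group that stands apart among the three, and the earlier pair alone could not show this. The carbon bearing the formyl group also counts, and its step is larger than any aryl swap here: an at least 14-fold lower number from compound 1 to compound 4 (1.16 log units; beyond the scatter). Compound 1 gives a limit of the assay and not a number: the limit of > 250000 nM in this assay, at which 1 of the 4 values shown sits.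

From the compounds shown here alone, it remains open whether the formyl group itself is needed, or whether a hydroxymethyl group or a carboxylic acid on that carbon would serve as well. Among the compounds shown here, a 4-chlorophenyl group would help show whether the single chlorine or the pair of chlorines goes with the higher number of compound 3.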